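The source may report more compounds than this note shows. Statements on the series, on what has been measured and on what is new or still open speak of the compounds shown alone.

Compound 1 `COc1cc(OC)c(OC)cc1/C=C/C(=O)c1cc(Cc2ccccc2)cc(Cc2ccccc2)c1` gives 2.17 ug/mL in a functional assay on cells (Erythrocyte, Rattus norvegicus) for inhibition, read by hemolysis, with a stated time of 1 h; a higher number here means a weaker inhibitor, a lower number a stronger inhibitor.
Compound 2 `COc1cc(OC)c(OC)cc1/C=C/C(=O)c1ccc(O)cc1O` gives 2.37 ug/mL in this assay.

Compound 2 has the higher of the two numbers, but its gap to compound 1 lies within the scatter, so the two are read as alike. Compound 3 `COc1ccc(C(=O)/C=C/c2cc(OC)c(OC)cc2OC)cc1` differs from compound 2 in one place: 4-methoxyphenyl in place of 2,4-dihydroxyphenyl on a carbonyl carbon. Because compound 1 gives 2.17 ug/mL with a quite different group at that same position, the change is expected to matter little. The step of a 1.2-fold higher number from compound 2 to compound 3 (0.07 log units; within the scatter) is expected to stay within the scatter. Compound 3 is expected to give about 2.8 ug/mL, within 1.2 ug/mL to 7 ug/mL.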

Compound 3, half-maximal inhibitory concentration: 2.18 ug/mL
Compound 3: middle estimate off by 1.3-fold (0.11 log units), on the high side; the measured number falls inside the stated range.
By their numbers in this assay, from the lowest: compounds 1, 3 and 2 (each within the scatter of the next).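

The swap of 2,4-dihydroxyphenyl for 4-methoxyphenyl on a carbonyl carbon gives a 1.1-fold lower number from compound 2 to compound 3 (0.04 log units; within the scatter) in this assay. At this position, then, the result does not depend on the hydrogen-bond donors of 2,4-dihydroxyphenyl, since 4-methoxyphenyl carries none and the two compounds read alike. No measurement at hand bears on why these groups read alike.

All the groups compared so far at this position are built on an aromatic ring of carbon only. On these data alone, it remains open whether a group such as an amine or a carboxylic acid in that place would also read alike.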